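This account rests on a few compounds, and the source may have more. Where it says the series, first, only, none or still open, it means among the compounds named here.

In an assay on HEK293 cells for binding affinity to 5-hydroxytryptamine receptor 7 (Homo sapiens), read by radioligand binding, tested at 1 uM (a lower number here means less inhibition, a higher number more inhibition at the concentration tested (going by the name of the read-out)), compound 1 `CN1CCCN(CCn2ccc3ccc(F)cc32)CC1` gives 60%, while compound 2 `CN1CCCN(CCn2ccc3ccc(C(N)=O)cc32)CC1` gives 33%, the lower of the two numbers. For the measured compounds named here, the step of a number 27 percentage points lower from compound 1 to compound 2 (beyond the scatter) is the only measured comparison available. Compound 3 `CN1CCCN(CCn2ccc3ccc(C(F)(F)F)cc32)CC1` differs from compound 2 by trifluoromethyl in place of carbamoyl on an aromatic carbon. Going by the values given here, no measured step involves a trifluoromethyl group, so the fluoro-to-carbamoyl step is the sole guide, and it leaves the direction for compound 3 uncertain but points upward. Compound 3 is therefore expected to show a step of a number 17 percentage points higher from compound 2 to compound 3 (beyond the scatter). The estimated value of compound 3 is 50%, within a range from 25% to 75%.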

Compound 3, a percentage reported as inhibition, at one concentration (the size of the read-out at that concentration, not a potency): 89%
Estimate against measurement, compound 3: 39 percentage points below; the measured number lies above the stated range.
By their numbers in this assay, from the lowest: compound 2; then compound 1; then compound 3.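

At this aromatic carbon, trifluoromethyl in place of carbamoyl gives a number 56 percentage points higher from compound 2 to compound 3 (beyond the scatter) and trifluoromethyl in place of fluoro gives a number 29 percentage points higher from compound 1 to compound 3 (beyond the scatter). Replacing fluoro here therefore does not only lower the number: carbamoyl lowers it, trifluoromethyl raises it, and the three groups rank carbamoyl, fluoro, trifluoromethyl from the lowest. Nothing available explains this order. Where a nitrile, a methoxy group or a carboxylic acid would fall in that order stays open. So does whether the same order holds at other aromatic carbons of the shared core.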